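The source may report more compounds than this note shows. Statements on the series, on what has been measured and on what is new or still open speak of the compounds shown alone.

Within the data shown here, compound 1 `C#CCNC1CCc2c(NCc3cccc(C(F)(F)F)c3)cccc21` is the only member of this small set with a measured number: in an ADME assay on isolated protein for inhibition of Amine oxidase [flavin-containing] B (Homo sapiens) (a lower number here means a stronger inhibitor, a higher number a weaker inhibitor), compound 1 gives 11300 nM. Compound 2 `C#CCNC1CCc2c(SCCc3ccc(F)c(F)c3)cccc21` shares the core of compound 1, but in this assay compound 2 has only "not determined" (no result reported) as its entry, so it stands nowhere on the numbers shown. Compound 3 `C#CCNC1CCc2c(SCCc3ccc(OC)cc3)cccc21` differs from compound 2 by 4-methoxyphenyl in place of 3,4-difluorophenyl on a saturated chain carbon, two bonds along the chain from a sulfur. Among the measured compounds shown here, since no value for compound 2 exists and no step is measured, no direction can be read from the data; no shift beyond the usual scatter is expected in this assay. Compound 3 is estimated at 6000 nM, within 1000 nM to 30000 nM.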

Compound 3, half-maximal inhibitory concentration: 4590 nM
The estimate for compound 3 lay 1.3-fold (0.12 log units) above the measured number; measured number inside the range.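

No step can be read from compound 2 to compound 3, since compound 2 has no number to compare. On these data alone, what 4-methoxyphenyl in place of 3,4-difluorophenyl does in this assay stays open. No supporting evidence bears on this result.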